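Alkoxy variation on the shared aminoquinoline-type core

The source may report more compounds than this note shows. Statements on the series, on what has been measured and on what is new or still open speak of the compounds shown alone.

Compound 1 `CCOCCOc1cccc2ccc(N)nc12` carries an ethoxyethoxy chain on the aromatic oxygen. In an assay on cells with melanin-concentrating hormone receptor 1 (Homo sapiens) as the target, read by radioligand binding (on this read-out lower numbers stand for stronger inhibition and higher numbers for weaker inhibition), compound 1 reaches only the assay limit of > 2000 nM, so no number is known for it (the limit of > 2000 nM in this assay, at which 1 of the 3 values shown sits). Compound 2 `CCC(C)COc1cccc2ccc(N)nc12` gives 36 nM in this assay. Compound 3 `CCCCOc1cccc2ccc(N)nc12`, with a plain butyl chain, gives 789 nM in this assay and stands highest of the two numbers measured; the step of a 22-fold higher number from compound 2 to compound 3 (1.34 log units; beyond the scatter) is large, and the steps of an at least 55-fold lower number from compound 1 to compound 2 (1.74 log units; beyond the scatter) and an at least 2.5-fold lower number from compound 1 to compound 3 (0.40 log units; beyond the scatter) both run downward from the limit.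

Compound 4 `Nc1ccc2cccc(OC3CCCC3)c2n1` is not yet measured. The change is cyclopentyl in place of butyl on an oxygen on an aromatic ring. Among the compounds with values here, the closest measured step is the loss of the methyl branch from compound 2 to compound 3 a 22-fold higher number from compound 2 to compound 3 (1.34 log units; beyond the scatter), which raised the number strongly; the cyclopentyl of compound 4 restores branching at the carbon on the oxygen, as in compound 2, but within a ring, for which no direct precedent exists. The step of an at least 2.5-fold lower number from compound 1 to compound 3 (0.40 log units; beyond the scatter) adds only that the simpler carbon chain of compound 3 fared better than the ether chain of compound 1.

Compound 4 is therefore expected to give a lower number than compound 3 in this assay, a step of about a 13-fold lower number from compound 3 to compound 4 (1.12 log units; beyond the scatter). The estimate for compound 4 is 60 nM, within 15 nM to 300 nM.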

Compound 4, half-maximal inhibitory concentration: > 2000 nM
Compound 4: no number, only a limit; the forecaster's own chance of this, stated with the estimate: 2%; middle value at least 33-fold (1.52 log units) away from the limit.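

Compound 4 gives > 2000 nM in this assay, which is a limit of the assay and not a number: the limit of > 2000 nM in this assay, at which 2 of the 4 values shown sit.

Among the carbon-only groups on this oxygen, the open chains give measured numbers, while the cyclopentyl ring does not. Cyclopentyl in place of 2-methylbutyl brings an at least 55-fold higher number from compound 2 to compound 4 (1.74 log units; beyond the scatter), and cyclopentyl in place of butyl brings an at least 2.5-fold higher number from compound 3 to compound 4 (0.40 log units; beyond the scatter), so the gain seen with the methyl branch of compound 2 does not extend to this ring, and the ring falls behind even the unbranched chain. The step involving compound 1 cannot be read, since it joins two limits.

On these data alone, what remains open is whether this loss belongs to rings on this oxygen in general or to cyclopentyl alone; cyclobutyl, cyclohexyl or cyclopentylmethyl would separate those cases. Also open, as far as these compounds go, is how far the branched-chain result extends, which a longer chain such as 3-methylpentyl, or a 2-methylbutyl chain ending in an amine, would test.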